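The source may report more compounds than this note shows. Statements on the series, on what has been measured and on what is new or still open speak of the compounds shown alone.

Measured so far:
- compound 1 `CCC(=O)Oc1c(Oc2ccccc2)c(Oc2ccccc2)c(OC(=O)CC)c2ccccc12`: 5.8
- compound 2 `COc1c(OC)c(OC(C)=O)c2cc(Br)ccc2c1OC(C)=O`: 3.39
- compound 3 `CC(=O)Oc1c(Oc2ccccc2)c(Oc2ccccc2)c(OC(C)=O)c2cc(Cl)ccc12`: 5.6

In a physicochemical assay for lipophilicity (on this read-out higher numbers stand for higher lipophilicity and lower numbers for lower lipophilicity), compound 1 gives 5.8. That number cannot be told apart from compound 3 at 5.6, since the two lie within the usual scatter of repeated measurements. Compound 2, at 3.39, lies lower than compound 1 by much more than that scatter.

The next compound to be measured is compound 4 `CCC(=O)Oc1c(Oc2ccccc2)c(Oc2ccccc2)c(OC(=O)CC)c2cc(Cl)ccc12`. It keeps the core and the two propionyl ester chains of compound 1 and makes one change: chloro in place of hydrogen on an aromatic carbon. In words, this is chloro in place of hydrogen on an aromatic carbon.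

For the measured compounds named here, no measured pair here differs by this change alone, so the size of the step is a judgement. Compound 3 already carries the chloro at the same place, but with acetyl ester chains, and it gives 5.6. Compound 4 combines that chloro with the ester chains of compound 1, so a rise beyond the scatter in this assay is expected. The estimated change is a number 0.60 log units higher from compound 1 to compound 4 (beyond the scatter). For compound 4 the expected value is 6.4, with an estimated range from 6 to 6.8.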

Compound 4, partition coefficient: 6.6
The estimate for compound 4 lay 0.20 log units below the measured number; measured number inside the range.
By their numbers in this assay, from the lowest: compound 2; then compounds 3 and 1 (each within the scatter of the next); then compound 4.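

For the compounds shown here, replacing hydrogen with chloro on an aromatic carbon of the shared core, with both propionyl ester chains kept, gives the first direct reading of this change in this assay (a number 0.80 log units higher from compound 1 to compound 4 (beyond the scatter)). The earlier compounds shown here could not show this, as no pair among them differed in one place only. Here a single added heavy atom at this place, meta to a fused ring and para to a fused ring, moves the number by more than repeat measurements would, though nothing available explains the rise.

A single pair cannot show whether the step keeps its size with other ester chains, such as the acetyl chains of compound 3, or at another aromatic carbon of the core. Also open, as far as these compounds go, is how fluoro, an amine or a carboxylic acid on this same aromatic carbon would compare with hydrogen and chloro in this assay, and whether a longer ester chain such as butyryl would alter the picture.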